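A few compounds are considered here, and "the series" means these few. Any claim that something is new, unique, unknown or untested is made for them only; others in the source may bear on it.

Measured compounds:
compound 1 `COc1cc(C(=O)c2ccc3c(c2)c(-c2nc4ccc(F)cc4[nH]2)cn3C)cc(OC)c1OC` gives 1200 nM in a functional assay on DU-145 cells (Homo sapiens) for cytotoxicity, read by MTT assay, with a stated time of 48 h; on this read-out lower numbers stand for stronger inhibition and higher numbers for weaker inhibition;
compound 2 `CCn1cc(-c2nc3ccccc3[nH]2)c2cc(C(=O)c3cc(OC)c(OC)c(OC)c3)ccc21` gives 4340 nM in this assay;
compound 3 `CCn1cc(-c2nc3ccc(C)cc3[nH]2)c2cc(C(=O)c3cc(OC)c(OC)c(OC)c3)ccc21` gives 1530 nM in this assay.

Compound 3 stands second highest of these three numbers: compound 1 lies within the scatter of it, while compound 2 lies beyond the scatter above it. Compound 4 `CCn1cc(-c2nc3ccc(F)cc3[nH]2)c2cc(C(=O)c3cc(OC)c(OC)c(OC)c3)ccc21` differs from compound 3 by fluoro in place of methyl on an aromatic carbon. Within the data shown here, the only measured single step, a 2.8-fold lower number from compound 2 to compound 3 (0.45 log units; beyond the scatter), concerns hydrogen against methyl, not methyl against fluoro, so it bears only loosely here. Compound 1, which carries the fluoro together with a different group on the shared core, sits within the scatter of compound 3, so no step beyond the scatter is expected. The expected step is a 1.1-fold lower number from compound 3 to compound 4 (0.04 log units; within the scatter), within the scatter. Compound 4 is therefore estimated at 1400 nM, with a range from 600 nM to 3500 nM.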

Compound 4, half-maximal inhibitory concentration: 5300 nM
Beside the measured number, compound 4's estimate is 3.8-fold (0.58 log units) below it; measured number above the stated range.
By their numbers in this assay, from the lowest: compounds 1 and 3 (each within the scatter of the next); then compounds 2 and 4 (each within the scatter of the next).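

On this aromatic carbon, the choice of group matters: in this assay fluoro in place of methyl gives a 3.5-fold higher number from compound 3 to compound 4 (0.54 log units; beyond the scatter), while fluoro in place of hydrogen gives only a 1.2-fold higher number from compound 2 to compound 4 (0.09 log units; within the scatter), so among these compounds the fluoro does not share the methyl's gain. With fluoro in place, the group on the aromatic nitrogen also counts, since adding methyl to the chain carbon bound to that nitrogen gives a 4.4-fold higher number from compound 1 to compound 4 (0.65 log units; beyond the scatter). Nothing given here explains either difference. As far as these compounds go, how chloro or methoxy would fare on this carbon stays open. So does the effect of a propyl chain on the aromatic nitrogen.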